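This account rests on a few compounds, and the source may have more. Where it says the series, first, only, none or still open, it means among the compounds named here.

Compound 2 `CC(=O)Nc1c(C#N)c(-c2ccccc2)cn1-c1ccc(S(=O)(=O)Nc2nccs2)cc1` was tested in a functional assay on HepG2 cells (Homo sapiens) for inhibition, read by sulforhodamine B assay, with a stated time of 24 h (a higher number here means a weaker inhibitor, a lower number a stronger inhibitor), and gives 4020 nM. Its companion, compound 1 `N#Cc1c(-c2ccccc2)cn(-c2ccc(S(=O)(=O)Nc3ccccn3)cc2)c1N`, gives 5300 nM in this assay; the two numbers lie within the usual scatter of each other, so neither can be called the stronger inhibitor. Compound 3 `CC(=O)Nc1c(C#N)c(-c2ccccc2)cn1-c1ccc(S(=O)(=O)Nc2ccccn2)cc1` has not yet been measured. It differs from compound 2 in one place: pyridin-2-yl in place of 1,3-thiazol-2-yl on a sulfonamide nitrogen. Among the measured compounds shown here, no measured pair shows this exchange on its own, so only a small step, none beyond the scatter, is expected, a 1.2-fold higher number from compound 2 to compound 3 (0.09 log units; within the scatter). Compound 3 is therefore estimated to give 5000 nM in this assay, between 2000 nM and 12000 nM.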

Compound 3, half-maximal inhibitory concentration: 3490 nM
Compound 3: middle estimate off by 1.4-fold (0.16 log units), on the high side; low and high end bracket the measured number.
By their numbers in this assay, from the lowest: compounds 3, 2 and 1 (each within the scatter of the next).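

The exchange of 1,3-thiazol-2-yl for pyridin-2-yl on a sulfonamide nitrogen gives a 1.2-fold lower number from compound 2 to compound 3 (0.06 log units; within the scatter) in this assay and so, in this pair, does not separate the two rings. Acetyl in place of hydrogen on a nitrogen on an aromatic ring gives a 1.5-fold lower number from compound 1 to compound 3 (0.18 log units; within the scatter) and is also not resolved from repeat measurements. No supporting measurement bears on either result. The compounds shown leave open whether a methyl group or plain phenyl on the sulfonamide nitrogen, or a longer acyl chain such as butanoyl in place of acetyl, would move the number beyond the scatter.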